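Fluoro for trifluoromethyl and the solubility limit

A few compounds are considered here, and "the series" means these few. Any claim that something is new, unique, unknown or untested is made for them only; others in the source may bear on it.

Measured compounds:
Compound 1 `Fc1ccc(Nc2cc3[nH]c(Nc4ccc(N5CCN(CC6CC6)CC5)cn4)nc3cn2)cc1C(F)(F)F`: 75000 nM
Compound 2 `Fc1ccc(Nc2cc3[nH]c(Nc4ccc(N5CCN(CC6CC6)CC5)cn4)nc3cn2)cc1F`: 10000 nM
Compound 3 `O=C(c1ccnc(Nc2nc3cnc(Nc4ccc(F)c(C(F)(F)F)c4)cc3[nH]2)c1)N1CCN(C2CC2)CC1`: < 5000 nM

Of the compounds shown here, three have been measured in a physicochemical assay for solubility, read by HPLC, using the shake flask method, in phosphate buffer, measured as kinetic solubility, with a stated time of 20 h, at pH 6.5; a lower number here means a less soluble compound, a higher number a more soluble compound. Compound 1 `Fc1ccc(Nc2cc3[nH]c(Nc4ccc(N5CCN(CC6CC6)CC5)cn4)nc3cn2)cc1C(F)(F)F` gives 75000 nM in this assay. Compound 2 `Fc1ccc(Nc2cc3[nH]c(Nc4ccc(N5CCN(CC6CC6)CC5)cn4)nc3cn2)cc1F`, which carries fluoro in place of trifluoromethyl on an aromatic carbon, gives 10000 nM. The step of a 7.5-fold lower number from compound 1 to compound 2 (0.88 log units; beyond the scatter) is the only measured step among these compounds. Compound 3 `O=C(c1ccnc(Nc2nc3cnc(Nc4ccc(F)c(C(F)(F)F)c4)cc3[nH]2)c1)N1CCN(C2CC2)CC1` has a different core from compound 1; the difference between the two cores is not broken down here. For compound 3 this assay reports only a limit, < 5000 nM, and one of the three values sits at the limit of < 5000 nM in this assay, at which 1 of the 3 values shown sits.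

Compound 4 `O=C(c1ccnc(Nc2nc3cnc(Nc4ccc(F)c(F)c4)cc3[nH]2)c1)N1CCN(C2CC2)CC1` is not yet measured. It differs from compound 3 by fluoro in place of trifluoromethyl on an aromatic carbon, the same kind of change as that from compound 1 to compound 2. Since that measured step was a 7.5-fold lower number from compound 1 to compound 2 (0.88 log units; beyond the scatter), the step that the limit leaves unreadable from compound 3 to compound 4 is expected to be of a comparable size. Compound 4 is therefore expected to give about 1500 nM in this assay, between 300 nM and 5000 nM, and most likely again only a limit is reported.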

Compound 4, solubility: < 5000 nM
Compound 4 gave a limit, no number; the forecaster's own chance of this, stated with the estimate: 85%; the middle value is on the limit's open side.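

In this assay compound 4 gave only a limit, < 5000 nM. Within the data shown here, compound 3 also stands at a limit, so no step between compound 3 and compound 4 can be read: the limit of < 5000 nM in this assay, at which 2 of the 4 values shown sit. The compounds shown leave open whether fluoro in place of trifluoromethyl changes the number on the core of compound 3 as it does on the core of compound 1.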